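Trimming the aryl chain by one carbon

This account rests on a few compounds, and the source may have more. Where it says the series, first, only, none or still open, it means among the compounds named here.

For the measured compounds named here, in a functional assay on L1210 cells (Mus musculus) for antiproliferative activity, read by MTT assay, with a stated time of 2 days (on this read-out higher numbers stand for weaker inhibition and lower numbers for stronger inhibition), compound 2 `CCCCCc1ccc(C#Cc2cn(C/C=C/CN3C(=O)c4ccccc4C3=O)c(=O)[nH]c2=O)cc1` gives 39000 nM, the only number so far. Compound 1 `CCCCCCCCC#Cc1cn(C/C=C/CN2C(=O)c3ccccc3C2=O)c(=O)[nH]c1=O` reaches only a limit, > 250000 nM. Going by the values given here, the single measured step, an at least 6.4-fold lower number from compound 1 to compound 2 (0.80 log units; beyond the scatter), is bounded by the limit of > 250000 nM in this assay, at which 1 of the 2 values shown sits, and alters a different part of the molecule. Compound 3 `CCCCc1ccc(C#Cc2cn(C/C=C/CN3C(=O)c4ccccc4C3=O)c(=O)[nH]c2=O)cc1` differs from compound 2 by hydrogen in place of methyl on a saturated chain carbon, four bonds along the chain from an aromatic carbon. Among the compounds with values here, no measured step bears on this cut, so a step within the scatter is expected, a 1.3-fold higher number from compound 2 to compound 3 (0.11 log units; within the scatter). Compound 3 is therefore estimated at 50000 nM, with a range from 20000 nM to 130000 nM.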

Compound 3, half-maximal inhibitory concentration: 42000 nM
Compound 3: the middle estimate sits 1.2-fold (0.08 log units) above what was measured; the measured number falls inside the stated range.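

Hydrogen in place of methyl on a saturated chain carbon, four bonds along the chain from an aromatic carbon, is tolerated in this assay, with a 1.1-fold higher number from compound 2 to compound 3 (0.03 log units; within the scatter). The advantage of the arylalkynyl substituent over octyl survives with the shorter 4-butylphenyl group, with an at least 5.9-fold lower number from compound 1 to compound 3 (0.77 log units; beyond the scatter). The value of compound 1 is a limit, so this step gives only a bound: the limit of > 250000 nM in this assay, at which 1 of the 3 values shown sits.

Still open, on these data alone, is how far the alkyl chain on the phenyl ring can be trimmed before the number moves beyond the scatter, as with an ethyl or methyl group. Also open, as far as these compounds go, is whether an amine or a carboxylic acid on that chain would be tolerated.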